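Carbamate side chain replaced by an oxadiazole ketone

The source may report more compounds than this note shows. Statements on the series, on what has been measured and on what is new or still open speak of the compounds shown alone.

Compound 2 `Cc1nc(S(C)(=O)=O)ccc1Oc1ncnc(OC2CCN(C(=O)O[C@H](C)C(F)(F)F)CC2)c1F` gives 110 nM in a functional assay on isolated protein for inhibition of Glucose-dependent insulinotropic receptor (Rattus norvegicus), read by HTRF and cAMP accumulation; on this read-out higher numbers stand for an effect only at larger amounts of compound and lower numbers for an effect already at smaller amounts. Among the three measured compounds it stands second highest. Compound 3 `Cc1nc(S(C)(=O)=O)ccc1Oc1ncnc(OC2CCN(C(=O)O[C@@H](C)C(F)(F)F)CC2)c1F` gives 109 nM; the step of a 1.0-fold lower number from compound 2 to compound 3 (0.00 log units; within the scatter) is explained by the fact that compounds 2 and 3 differ only in the configuration as drawn. Compound 1 `Cc1nc(S(C)(=O)=O)ccc1Oc1ncnc(OC2CCN(C(=O)OC(C)(C)C#N)CC2)c1F` gives 1320 nM, and the step of a 12-fold lower number from compound 1 to compound 2 (1.08 log units; beyond the scatter) shows the group on the carbamate oxygen to be a sensitive position. Compound 4 `Cc1nc(S(C)(=O)=O)ccc1Oc1ncnc(OC2CCN(C(=O)c3noc(C(C)C)n3)CC2)c1F` carries the change (5-isopropyl-1,2,4-oxadiazol-3-yl in place of 1-(trifluoromethyl)ethoxy on a carbonyl carbon). Among the compounds with values here, only the step from compound 1 to compound 2 bears on this position, and it exchanged one alkoxy group for another; no measured step replaces the alkoxy with a ring. The estimate for compound 4 is therefore uncertain: 250 nM, between 40 nM and 1600 nM, meaning an expected step of a 2.3-fold higher number from compound 2 to compound 4 (0.36 log units; beyond the scatter).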

Compound 4, half-maximal effective concentration: 176 nM
The estimate for compound 4 lay 1.4-fold (0.15 log units) above the measured number; measured number inside the range.
By their numbers in this assay, from the lowest: compounds 3, 2 and 4 (each within the scatter of the next); then compound 1.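

With a ring in place of the alkoxy group on the carbonyl carbon, a 1.6-fold higher number from compound 2 to compound 4 (0.20 log units; within the scatter) and a 1.6-fold higher number from compound 3 to compound 4 (0.21 log units; within the scatter) show no readable difference from either 1-(trifluoromethyl)ethoxy compound. The carbonyl carbon therefore accepts 5-isopropyl-1,2,4-oxadiazol-3-yl as well as an alkoxy group, and a 7.5-fold lower number from compound 1 to compound 4 (0.88 log units; beyond the scatter) leaves the 1-cyano-1-methylethoxy compound apart from the other three. Nothing at hand accounts for this result.

Going by these compounds, whether the isopropyl group can give way to cyclopropyl or tert-butyl on the oxadiazole stays open. So does whether a phenyl or pyridine ring on the carbonyl carbon would serve equally.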